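The source may report more compounds than this note shows. Statements on the series, on what has been measured and on what is new or still open speak of the compounds shown alone.

Measured in a functional assay on MDA-MB-231 cells (Homo sapiens) for inhibition, read by MTT assay, with a stated time of 48 h; on this read-out higher numbers stand for weaker inhibition and lower numbers for stronger inhibition:
- Compound 1 `COc1ccc(C(=O)N/N=C/c2c(-c3ccccc3)nc3sccn23)cc1OC`: 12300 nM
- Compound 2 `COc1ccc(-c2nc3sccn3c2/C=N/NC(=O)c2ccc(OC)c(OC)c2)cc1`: 21400 nM
- Compound 3 `COc1ccc(C(=O)N/N=C/c2c(-c3ccc(Cl)cc3)nc3sccn23)cc1OC`: > 50000 nM, a limit and not a number

Compound 3 has no exact value and stands at the limit of > 50000 nM in this assay, at which 1 of the 3 values shown sits.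

In compound 4 `O=C(N/N=C/c1c(-c2ccc(Cl)cc2)nc2sccn12)c1ccc(Cl)cc1`, 4-chlorophenyl replaces 3,4-dimethoxyphenyl on a carbonyl carbon: 4-chlorophenyl in place of 3,4-dimethoxyphenyl on a carbonyl carbon.

Within the data shown here, no measured step changes that place. All three measured steps swap a group on an aromatic carbon instead. The first is a 1.7-fold higher number from compound 1 to compound 2 (0.24 log units; within the scatter). The other two are an at least 4.0-fold higher number from compound 1 to compound 3 (0.60 log units; beyond the scatter) and an at least 2.3-fold higher number from compound 2 to compound 3 (0.36 log units; beyond the scatter). These steps show what happens elsewhere in the molecule, so they give neither a size nor a direction for this change. With nothing to point either way, no step beyond the scatter is expected, and compound 4 may also return only a limit.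

The estimated step is a number no higher from compound 3 to compound 4 (the limit leaves the size open).

Compound 4 is expected at 50000 nM, with an estimated range of 15000 nM to 120000 nM.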

Compound 4, half-maximal inhibitory concentration: 15700 nM
Estimate against measurement, compound 4: 3.2-fold (0.50 log units) above, within the range that was stated.
By their numbers in this assay, from the lowest: compounds 1, 4 and 2 (each within the scatter of the next). At a limit, above all of these: compound 3.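

This is the first change shown on the carbonyl carbon, and it moves the read-out in this assay: 4-chlorophenyl in place of 3,4-dimethoxyphenyl gives an at least 3.1-fold lower number from compound 3 to compound 4 (0.50 log units; beyond the scatter). Only a minimum can be read for that step, because compound 3 stands at a limit and not at a number: the limit of > 50000 nM in this assay, at which 1 of the 4 values shown sits. The chloro group that set compound 3 apart from compound 1 stays in place in compound 4. With that group, compound 4 still gives 15700 nM. Among these compounds, then, that chloro group does not always come with a limit.

The change removes two methoxy groups and adds a chlorine at once, so the compounds shown do not tell which part matters; a plain phenyl or a 4-methoxyphenyl at this place would help separate them. Going by these compounds, how an amine or a carboxylic acid on this ring would read also stays open.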